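Solubility notes: fluoro for pyrrolidinylcarbonyl on compound 1

A few compounds are considered here, and "the series" means these few. Any claim that something is new, unique, unknown or untested is made for them only; others in the source may bear on it.

Measured so far in a physicochemical assay for solubility, in phosphate buffer, at pH 7.4; a higher number here means a more soluble compound, a lower number a less soluble compound:
- compound 1 `COc1cc(C(=O)N2CCCC2)ccc1-c1ccnc2[nH]c(C3CCOCC3)cc12`: 15000 nM
- compound 2 `CC(=O)N1CCC(c2cc3c(-c4ccc(=O)n(C(C)C)c4)ccnc3[nH]2)CC1`: 27000 nM
- compound 3 `CC(C)Cn1cc(-c2ccnc3[nH]c(C4CCN(CC(=O)N(C)C)CC4)cc23)ccc1=O`: 390000 nM

Compound 1 stands lowest of the three numbers. Its nearest neighbour is compound 2, whose value lies within the scatter of compound 1, so no order between these two is claimed. Compound 3 lies beyond the scatter above compound 1. Among the measured compounds shown here, no two measured compounds differ in a single place, so no measured step is available to lean on.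

Compound 4 `COc1cc(F)ccc1-c1ccnc2[nH]c(C3CCOCC3)cc12` is not yet measured. It differs from compound 1 in one place: fluoro in place of (pyrrolidin-1-yl)carbonyl on an aromatic carbon. The group that leaves carries one hydrogen-bond acceptor and a five-membered non-aromatic ring; what enters is a single atom with no acceptor. A step down in this assay is expected for compound 4, beyond the scatter, the expected step being a 3.8-fold lower number from compound 1 to compound 4 (0.57 log units; beyond the scatter). For compound 4 the estimate in this assay is 4000 nM, with a range of 1000 nM to 15000 nM.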

Compound 4, solubility: 97000 nM
The estimate for compound 4 lay 24-fold (1.38 log units) below the measured number; the whole stated range lies below it.
By their numbers in this assay, from the lowest: compounds 1 and 2 (each within the scatter of the next); then compound 4; then compound 3.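

In this assay, among the compounds shown here, the first single-place step is upward, a 6.5-fold higher number from compound 1 to compound 4 (0.81 log units; beyond the scatter), with fluoro in place of (pyrrolidin-1-yl)carbonyl on the aromatic carbon meta to a methoxy group. On this core, then, the hydrogen-bond acceptor and the five-membered non-aromatic ring of the leaving group are not needed for a higher number at this position. No measurement at hand speaks to the cause of this step.

From the compounds shown here alone, whether the rise belongs to fluoro itself or simply to the loss of the (pyrrolidin-1-yl)carbonyl stays open, and a plain hydrogen or a chlorine at this position would separate the two. Also open, going by these compounds, is how a carboxylic acid or an aminomethyl group would read here, and whether a smaller dimethylamide would follow compound 1 or compound 4.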